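Swapping an aromatic ring for a saturated one

The source may report more compounds than this note shows. Statements on the series, on what has been measured and on what is new or still open speak of the compounds shown alone.

Compound 2 `O=C(Nc1ccccc1)Nc1ccc2c(c1)COC2=O` carries a phenyl on an amide-type nitrogen attached to the shared core. In a functional assay on cells (T-cell, Mus musculus) for inhibition (on this read-out higher numbers stand for weaker inhibition and lower numbers for stronger inhibition), compound 2 gives 7090 nM. Among the numbers shown it stands highest; its nearest neighbour is compound 1 `CC(C)c1ccc(/C=C/C(=O)Nc2ccc3c(c2)COC3=O)cc1`, which in this assay gives 1590 nM, a gap beyond the usual scatter. Compound 3 `CN(C(=O)Nc1ccc2c(c1)COC2=O)c1ccccc1` carries a methyl in place of hydrogen on an amide-type nitrogen, and in this assay compound 3 reaches only a limit of > 100000 nM. That change produced an at least 14-fold higher number from compound 2 to compound 3 (1.14 log units; beyond the scatter), a result resting on (the limit of > 100000 nM in this assay, at which 1 of the 3 values shown sits).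

Compound 4 `O=C(Nc1ccc2c(c1)COC2=O)NC1CCCCC1` differs from compound 2 by cyclohexyl in place of phenyl on an amide-type nitrogen. Going by the values given here, no measured step shows this kind of exchange: the only step recorded, adding a methyl to the same nitrogen, alters something else and so gives no direct guide to the direction or size expected here. With nothing pointing clearly either way, a step of about a 1.3-fold higher number from compound 2 to compound 4 (0.10 log units; within the scatter) is expected, accompanied by considerable uncertainty. The estimate for compound 4 in this assay is 9000 nM, with a likely range from 2000 nM to 45000 nM.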

Compound 4, half-maximal inhibitory concentration: 12700 nM
Estimate against measurement, compound 4: 1.4-fold (0.15 log units) below, and the stated range covers the measured number.
By their numbers in this assay, from the lowest: compound 1; then compounds 2 and 4 (each within the scatter of the next). At a limit, above all of these: compound 3.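

In this assay, cyclohexyl in place of phenyl on an amide-type nitrogen gives a 1.8-fold higher number from compound 2 to compound 4 (0.25 log units; within the scatter). An aromatic ring on this nitrogen is therefore not needed to keep the read-out within the scatter of compound 2, and a saturated ring of the same six carbons serves as well here. The earlier methyl step showed how much this nitrogen can matter, while this exchange shows that the ring attached to it can change in kind without a measurable shift, though nothing shown here explains why.

Going by these compounds, what remains open is whether any ring is needed on this nitrogen, which a butyl chain could test. Also open, on these data alone, is how this position would respond to a cyclohexyl ring carrying an amine or a carboxylic acid.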